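The source may hold more compounds than are shown below. What is called first, only, known or untested is meant among the compounds shown, and "the series" means these compounds.

Compound 1 `NC[C@@H]1CCCc2cc(S(=O)(=O)Cc3ccccc3)ccc21`: 158 nM in an assay on isolated protein for displacement of a labelled ligand from 5-hydroxytryptamine receptor 6 (Homo sapiens); on this read-out lower numbers stand for stronger inhibition and higher numbers for weaker inhibition
Compound 2 `CNC[C@@H]1CCCc2cc(S(=O)(=O)c3cc[nH]c3)ccc21`: 0.159 nM
Compound 3 `O=C(NC[C@@H]1CCCc2cc(S(=O)(=O)c3cccc(F)c3)ccc21)c1ccc[nH]1`: 5.01 nM

All three numbers come from this assay, where a smaller number means a tighter hold on the receptor. Compound 3 stands second highest of the three, between compound 1 and compound 2, and its separation from each of those two lies beyond the usual scatter of repeated measurements. Compound 2 gives the lowest number of the set and compound 1 the highest.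

Compound 4 `CS(=O)(=O)NC[C@@H]1CCCc2cc(S(=O)(=O)c3cccc(F)c3)ccc21` has not yet been measured. Set against compound 3, the difference is methylsulfonyl in place of (1H-pyrrol-2-yl)carbonyl on an amine nitrogen. For the measured compounds named here, no measured pair in this set shows that same exchange, so how it plays out has to be judged from the three measured compounds alone. Compound 3 carries a five-membered aromatic ring with one hydrogen-bond donor at that position; in compound 4 this is replaced by a group with no ring, no donor and two acceptors.

Compound 4 is expected to give a somewhat higher number than compound 3, the step of a 4.0-fold higher number from compound 3 to compound 4 (0.60 log units; beyond the scatter) being expected to pass beyond the scatter while staying moderate. Compound 4 is therefore estimated at 20 nM, with a range from 4 nM to 100 nM.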

Compound 4, inhibition constant: 0.2 nM
Compound 4: the middle estimate sits 100-fold (2.00 log units) above what was measured, and the stated range ends above it.
By their numbers in this assay, from the lowest: compounds 2 and 4 (each within the scatter of the next); then compound 3; then compound 1.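

For the compounds shown here, exchanging (1H-pyrrol-2-yl)carbonyl for methylsulfonyl on the amine nitrogen gives, in this assay, a 25-fold lower number from compound 3 to compound 4 (1.40 log units; beyond the scatter), the first change in this set that can be read in one place, and it shows that the group on this nitrogen has a large bearing on the number. It also shows that tight holding on the receptor does not depend on the five-membered aromatic ring or its hydrogen-bond donor, since the smaller methylsulfonyl, with no ring and no donor, gives the lower number. Nothing at hand, whether a measured property or any other data, accounts for the size of this step.

The exchange replaces the carbonyl with a sulfonyl and removes the ring in a single move, which leaves open which of these matters; an acetyl group on the same nitrogen would separate the two, and an ethylsulfonyl group would test whether a longer chain on the sulfonyl is tolerated. Also open, going by these compounds, is whether the step would hold with the other groups on the ring sulfonyl, such as those of compound 1 and compound 2.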